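Amine replaced by a carboxylic acid on the side chain

A few compounds are considered here, and "the series" means these few. Any claim that something is new, unique, unknown or untested is made for them only; others in the source may bear on it.

Compound 1 `NCCCCCCOc1ccc2c(=O)c(-c3ccc(O)cc3)coc2c1` gives 100 nM in an assay (Cricetulus griseus) for inhibition of aldehyde dehydrogenase, mitochondrial (Homo sapiens) (on this read-out lower numbers stand for stronger inhibition and higher numbers for weaker inhibition), the lowest number of the three measured. Compound 2 `NCCCCOc1ccc2c(=O)c(-c3ccc(O)cc3)coc2c1` gives 250 nM and compound 3 `O=C(O)CCCCCOc1ccc2c(=O)cc(-c3ccc(O)cc3)oc2c1` gives 3500 nM. The step of a 2.5-fold higher number from compound 1 to compound 2 (0.40 log units; beyond the scatter), amino in place of 2-aminoethyl, cost modestly. Compound 4 `O=C(O)CCCCCCCCCOc1ccc2c(=O)c(-c3ccc(O)cc3)coc2c1` is unmeasured; it differs from compound 1 by 3-carboxypropyl in place of amino on a saturated chain carbon, six bonds along the chain from an oxygen on an aromatic ring. Among the compounds with values here, no measured step covers this change. Within the data shown here, the only reference is compound 3, which carries a carboxylic acid at the end of its chain on a different core, and its number in this assay stands far above that of compound 1. The step of a 15-fold higher number from compound 1 to compound 4 (1.18 log units; beyond the scatter) is therefore expected to weaken inhibition. Compound 4 is estimated at 1500 nM, within a range of 400 nM to 6000 nM.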

Compound 4, half-maximal inhibitory concentration: 50 nM
For compound 4 the middle estimate is 30-fold (1.48 log units) above the measured one; the measured number lies below the stated range.
By their numbers in this assay, from the lowest: compounds 4 and 1 (each within the scatter of the next); then compound 2; then compound 3.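

In this assay, the carboxylic acid at the end of the longer chain of compound 4 is accommodated on the core of compound 1: a 2.0-fold lower number from compound 1 to compound 4 (0.30 log units; within the scatter). Swapping the amine for the acid therefore need not weaken inhibition on this core when the chain is lengthened with it. Against the shorter amine chain the picture differs, a 5.0-fold lower number from compound 2 to compound 4 (0.70 log units; beyond the scatter), though chain length and end group change together in that step.

Still open, from the compounds shown here alone, is how an amine would compare on the longer chain of compound 4, and a carboxylic acid on the shorter chain of compound 2. Nothing available explains why the acid is accommodated here.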